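Thiazole for pyrimidine on the benzylic ether arm

The source may hold more compounds than are shown below. What is called first, only, known or untested is meant among the compounds shown, and "the series" means these compounds.

Measured in an in vitro ADME assay on microsomes from liver (Homo sapiens) for metabolic stability; on this read-out higher numbers stand for fast clearance and lower numbers for slow clearance:
- compound 1 `O=C(COCc1ccccc1)N1CCN(c2ccc(Cl)cc2Cl)CC1` gives 450 mL.min-1.g-1
- compound 2 `O=C(COCc1ncccn1)N1CCN(c2ccc(Cl)cc2Cl)CC1` gives 16 mL.min-1.g-1

Of the two measured compounds, compound 2 has the lower number at 16 mL.min-1.g-1. The next compound, compound 3 `O=C(COCc1cncs1)N1CCN(c2ccc(Cl)cc2Cl)CC1`, differs from it as follows: 1,3-thiazol-5-yl in place of pyrimidin-2-yl on a saturated chain carbon bound to an oxygen on a saturated carbon.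

Going by the values given here, one measured step bears on this change, at the same place in the structure: a 28-fold lower number from compound 1 to compound 2 (1.45 log units; beyond the scatter). There, pyrimidin-2-yl replaced phenyl, and the step was large and beyond the scatter. The ring in compound 3 is aromatic and holds hetero atoms, as pyrimidin-2-yl does and phenyl does not. Only part of a 28-fold lower number from compound 1 to compound 2 (1.45 log units; beyond the scatter) is therefore expected to be given back. Among the compounds with values here, no measured compound carries 1,3-thiazol-5-yl, so this expectation is loose. In this assay, the expected change is a moderately higher number, estimated as a 2.8-fold higher number from compound 2 to compound 3 (0.45 log units; beyond the scatter). For compound 3 the estimated value is 45 mL.min-1.g-1, with an expected range of 16 mL.min-1.g-1 to 130 mL.min-1.g-1.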

Compound 3, intrinsic clearance in microsomes: 73 mL.min-1.g-1
The estimate for compound 3 lay 1.6-fold (0.21 log units) below the measured number; the measured number falls inside the stated range.
By their numbers in this assay, from the lowest: compound 2; then compound 3; then compound 1.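

In this assay, the gain over phenyl at this place is not unique to pyrimidin-2-yl: 1,3-thiazol-5-yl also keeps a lower number, with a 6.2-fold lower number from compound 1 to compound 3 (0.79 log units; beyond the scatter). The two rings with hetero atoms are nevertheless not interchangeable, as a 4.6-fold higher number from compound 2 to compound 3 (0.66 log units; beyond the scatter) shows, so the identity of the ring matters as well as the presence of hetero atoms. This change alters ring size and swaps a nitrogen for a sulfur together, so the step cannot be assigned to either, and no measurement available here accounts for the difference.

Open, from the compounds shown here alone, is how a pyridine ring, with a single ring nitrogen, would read at this place, and whether 1,3-thiazol-2-yl would match 1,3-thiazol-5-yl. Also open, going by these compounds, is whether a saturated ring such as tetrahydropyran would keep the lower numbers.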